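This account rests on a few compounds, and the source may have more. Where it says the series, first, only, none or still open, it means among the compounds named here.

Measured so far in a functional assay on HepG2 cells (Homo sapiens) for antiproliferative activity, read by MTT assay, with a stated time of 48 h; a higher number here means a weaker inhibitor, a lower number a stronger inhibitor:
compound 1, `COC(=O)CN(C)c1nc(Nc2ccc(Cl)cc2)ncc1[N+](=O)[O-]`, gives 49800 nM.
compound 2, `CCOC(=O)CNc1nc(Nc2ccc(Cl)cc2)ncc1[N+](=O)[O-]`, gives only a limit of the assay, > 100000 nM.
compound 3, `CCOC(=O)CN(Cc1ccccc1)c1nc(Nc2ccc(Cl)cc2)ncc1[N+](=O)[O-]`, gives 30900 nM.

Compound 2 therefore has no number of its own, only (the limit of > 100000 nM in this assay, at which 1 of the 3 values shown sits). The two measured steps, an at least 2.0-fold higher number from compound 1 to compound 2 (0.30 log units; that floor lies within the scatter) and an at least 3.2-fold lower number from compound 2 to compound 3 (0.51 log units; beyond the scatter), both alter the amino side chain of the shared core and leave the 4-chlorophenyl untouched; neither of them informs the change now in question.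

Compound 4, `CCOC(=O)CNc1nc(Nc2ccc(OC)cc2)ncc1[N+](=O)[O-]`, differs from compound 2 by methoxy in place of chloro on an aromatic carbon. Among the measured compounds shown here, no measured step covers an exchange on this ring, so the direction of the step cannot be read from the series. With compound 2 at the limit and nothing pointing to a gain, compound 4 is expected to remain weak in this assay. The expected step is a step that the limit leaves unreadable from compound 2 to compound 4. For compound 4 the estimate is 120000 nM, with a range from 40000 nM to 350000 nM, and a good chance that only a limit is reported again.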

Compound 4, half-maximal inhibitory concentration: > 100000 nM
Compound 4 was reported as a limit (the forecaster's own chance of this, stated with the estimate: 60%); the middle value lies beyond the limit too.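

Compound 2 and compound 4 give no readable step in this assay, because each is reported only as a limit: the limit of > 100000 nM in this assay, at which 2 of the 4 values shown sit.

The compounds shown leave open how 4-chlorophenyl and 4-methoxyphenyl compare where the side chain gives a measurable value, as in compound 1 or compound 3.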